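Aryl substitution on the triazole nitrogen: compound 3

The source may report more compounds than this note shows. Statements on the series, on what has been measured and on what is new or still open speak of the compounds shown alone.

Working notes on the series. Compound 2 `COc1cc2c(Oc3ccc(NC(=O)c4cn(-c5ccccc5C)nn4)cc3F)ccnc2cc1OCCCN1CCC(C)CC1` gives 2380 nM in a functional assay on HT-29 cells (Homo sapiens) for cytotoxicity, read by MTT assay, with a stated time of 72 h (a lower number here means a stronger inhibitor, a higher number a weaker inhibitor), the highest of the two numbers in hand. Its nearest neighbour is compound 1 `COc1cc2c(Oc3ccc(NC(=O)c4cn(-c5ccccc5)nn4)cc3F)ccnc2cc1OCCCN1CCC(C)CC1`, which in this assay gives 190 nM; the single shown step, a 13-fold higher number from compound 1 to compound 2 (1.10 log units; beyond the scatter), is large and reads as methyl in place of hydrogen on an aromatic carbon. Compound 3 `COc1cc2c(Oc3ccc(NC(=O)c4cn(-c5c(Cl)cccc5Cl)nn4)cc3F)ccnc2cc1OCCCN1CCC(C)CC1` is not yet measured. It differs from compound 2 by 2,6-dichlorophenyl in place of 2-methylphenyl on an aromatic nitrogen. Within the data shown here, only the step from compound 1 to compound 2 bears on this change, and it showed that adding one group at this position costs a lot, so for compound 3 a further step upward, or at most no step beyond the scatter, is expected in this assay, as a 1.3-fold higher number from compound 2 to compound 3 (0.10 log units; within the scatter). The estimate for compound 3 in this assay is 3000 nM, with a range from 700 nM to 12000 nM.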

Compound 3, half-maximal inhibitory concentration: 1390 nM
Beside the measured number, compound 3's estimate is 2.2-fold (0.33 log units) above it, within the range that was stated.
By their numbers in this assay, from the lowest: compound 1; then compounds 3 and 2 (each within the scatter of the next).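

In this assay, the step of a 1.7-fold lower number from compound 2 to compound 3 (0.23 log units; within the scatter) leaves 2-methylphenyl and 2,6-dichlorophenyl on the aromatic nitrogen indistinguishable, even though one carries methyl and the other two chlorines. The rise over unsubstituted phenyl is therefore not confined to methyl: a 7.3-fold higher number from compound 1 to compound 3 (0.86 log units; beyond the scatter) is a second step beyond the scatter in the same direction, and neither substituted aryl compound goes against it. No supporting data bear on why these numbers fall as they do.

As far as these compounds go, whether a single chlorine on the phenyl would behave like 2,6-dichlorophenyl or give a number closer to that of compound 1 remains open. Also open, from the compounds shown here alone, is whether an amine or a carboxylic acid on that phenyl, or a longer chain in place of the ring, would follow the same pattern in this assay or break it.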